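Efficacy on the shared core: aromatic ring back onto the alkyne

The compounds below may be only part of what the source reports. "The series", "measured", "known", "first", "only" and "open" are said of these compounds alone.

Compound 2 `C[C@@H](NC(=O)c1ccc(C#CC2CCCC2)cn1)C(C)(C)O` and compound 1 `Cc1ccc(C#Cc2ccc(C(=O)N[C@H](C)C(C)(C)O)nc2)cc1` share the same core and differ only in the group on the triple-bonded carbon. In a functional assay on HEK293 cells for positive allosteric modulation of metabotropic glutamate receptor 5 (Rattus norvegicus), read by fluorescence and calcium flux (on this read-out lower numbers stand for smaller maximal responses and higher numbers for larger maximal responses), compound 2 gives 63.7% and compound 1 gives 63.1%, so the two values lie within the scatter of each other and neither separates from the other. For the measured compounds named here, the one measured step, a number 0.6 percentage points higher from compound 1 to compound 2 (within the scatter), is the only comparison so far.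

Compound 3 `C[C@@H](NC(=O)c1ccc(C#Cc2cccc(F)n2)cn1)C(C)(C)O` is not yet measured. It differs from compound 2 by 6-fluoropyridin-2-yl in place of cyclopentyl on a triple-bonded carbon. This change bears on the same position as the step from compound 1 to compound 2, which exchanged one ring for another without moving the number beyond the scatter; the present change again exchanges one ring for another at that position. Going by the values given here, no measured step at this position has left the scatter, so no step beyond the scatter is expected for compound 3 either. Compound 3 is therefore expected to give 63%, with a range of 45% to 80%. The step this estimate implies is expected to be a number 0.7 percentage points lower from compound 2 to compound 3 (within the scatter).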

Compound 3, largest response reached (reported as efficacy), in percent of the reference or control that the assay uses: 63%
Beside the measured number, compound 3's estimate shows no gap at the digits printed; measured number inside the range.
By their numbers in this assay, from the lowest: compounds 3, 1 and 2 (each within the scatter of the next).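

In this assay, for the compounds shown here, the 6-fluoropyridin-2-yl group is the only one of the three rings on the triple-bonded carbon that carries a hetero atom, yet it does not separate from either earlier group: replacing cyclopentyl gives a number 0.7 percentage points lower from compound 2 to compound 3 (within the scatter) and replacing 4-methylphenyl on the shared core gives a number 0.1 percentage points lower from compound 1 to compound 3 (within the scatter) in the same read-out. The position now holds a non-aromatic carbon ring, a methyl-bearing phenyl ring and a fluorinated aromatic ring with a nitrogen, and the hydrogen-bond acceptor entering in place of cyclopentyl comes with no step beyond the scatter. No supporting data are available to account for this flat result.

All three groups on the triple-bonded carbon are rings, so the compounds shown leave open whether an amine, a carboxylic acid or a longer chain at this position would stay within the scatter or leave it. Largest response reached is also the only read-out shown, so whether these three rings differ in any other measure of the series remains open.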